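Sulfonamide series on a shared core: three limits and a thiophene

The compounds below may be only part of what the source reports. "The series", "measured", "known", "first", "only" and "open" are said of these compounds alone.

Three compounds sharing one core have been run in an assay on isolated protein for inhibition of malate dehydrogenase, mitochondrial (Sus scrofa), with stated times of 45 min and 30 min; a lower number here means a stronger inhibitor, a higher number a weaker inhibitor. Compound 1 `Cc1ccc(S(=O)(=O)Nc2ccc3oc(-c4ccccc4)nc3c2)cc1` carries a 4-methylphenyl group on the sulfonyl sulfur, and in this assay compound 1 gives only a limit, > 63000 nM. Compound 2 `COc1cccc(S(=O)(=O)Nc2ccc3oc(-c4ccccc4)nc3c2)c1` bears a 3-methoxyphenyl group there, and compound 2 likewise returns a limit, > 63000 nM. Compound 3 `COc1ccccc1S(=O)(=O)Nc1ccc2oc(-c3ccccc3)nc2c1`, with a 2-methoxyphenyl on the sulfonyl sulfur, also gives a limit, > 63000 nM. Compound 3 thus stands nowhere distinct among the numbers shown: all three values sit at the limit of > 63000 nM in this assay, at which 3 of the 3 values shown sit, and the steps between them cannot be read: a step that the two limits leave unreadable from compound 1 to compound 2, a step that the two limits leave unreadable from compound 1 to compound 3, a step that the two limits leave unreadable from compound 2 to compound 3.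

Compound 4 `O=S(=O)(Nc1ccc2oc(-c3ccccc3)nc2c1)c1cccs1` is not yet measured. Its change from compound 3 is thiophen-2-yl in place of 2-methoxyphenyl on a sulfonyl sulfur. The measured steps all concern exchanges of the aromatic group on the sulfonyl sulfur, and none of them yielded a readable size, so they set no direction for this assay. With every measured compound at the limit, compound 4 is expected to remain there as well. The expected step that the limit leaves unreadable from compound 3 to compound 4 is meant as no readable change. Compound 4 is estimated at 100000 nM, with a range from 30000 nM to 300000 nM, most likely reported as a limit again.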

Compound 4, half-maximal inhibitory concentration: > 63000 nM
Compound 4: no number, only a limit; the forecaster's own chance of this, stated with the estimate: 85%; the middle value lies beyond the limit too.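

In this assay compound 4 gives > 63000 nM, which is a limit. The steps to compound 4 from compound 1, compound 2 and compound 3 therefore cannot be read: the limit of > 63000 nM in this assay, at which 4 of the 4 values shown sit.

The compounds shown leave open whether any group on the sulfonyl sulfur of the shared core gives a measurable value in this assay.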